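Swapping the phenylpropenyl arm for a pyrrolidine amide

The compounds below may be only part of what the source reports. "The series", "measured", "known", "first", "only" and "open" are said of these compounds alone.

Compound 1 `C=CCN1CCN(CC(=O)C(O)(c2ccccc2)C2CCCCC2)CC1` gives 25.6 nM
Compound 2 `O=C(CN1CCC(N2CCCC2)CC1)C(O)(c1ccccc1)C1CCCCC1` gives 349 nM
Compound 3 `O=C(CN1CCN(C/C=C\c2ccccc2)CC1)C(O)(c1ccccc1)C1CCC1` gives 9.92 nM

These three values come from a functional assay on ileum for antagonist activity at muscarinic acetylcholine receptor M3 (Cavia porcellus); on this read-out lower numbers stand for stronger inhibition and higher numbers for weaker inhibition. Compound 3 stands at the lowest number of the three: compound 1 sits higher by a margin beyond the scatter, and compound 2 sits far higher still, so compound 3 is the strongest inhibitor of the set on this read-out.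

Compound 4 `O=C(CN1CCN(CC(=O)C(O)(c2ccccc2)C2CCC2)CC1)N1CCCC1` has not been tested. It differs from compound 3 in one place: (pyrrolidin-1-yl)carbonyl in place of 2-phenylethenyl on a saturated chain carbon bound to an amine nitrogen in a ring. Seen one bond further out, the 3-phenylprop-2-en-1-yl chain becomes a ((pyrrolidin-1-yl)carbonyl)methyl chain. Among the measured compounds shown here, no measured pair shows this exact exchange. Compound 1, which lacks the phenyl-bearing chain, gives a higher number than compound 3, and compound 2, which carries a pyrrolidine ring in a different way, gives the highest number of all. On that basis the author expects a move to a higher number for compound 4, as the step of an 8.1-fold higher number from compound 3 to compound 4 (0.91 log units; beyond the scatter), beyond the scatter. The estimate for compound 4 in this assay is 80 nM, with a range from 20 nM to 400 nM.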

Compound 4, antagonist equilibrium constant: 210 nM
Compound 4: the middle estimate sits 2.6-fold (0.42 log units) below what was measured; measured number inside the range.
By their numbers in this assay, from the lowest: compound 3; then compound 1; then compounds 4 and 2 (each within the scatter of the next).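

In this assay, putting (pyrrolidin-1-yl)carbonyl in place of 2-phenylethenyl on a saturated chain carbon bound to an amine nitrogen in a ring gives a 21-fold higher number from compound 3 to compound 4 (1.33 log units; beyond the scatter), a large loss of inhibition. Among the compounds shown here, this is the first direct exchange at this place with the rest of the molecule held constant, and it shows that the number depends strongly on the group carried there. Nothing available explains why the number rises so far.

For the compounds shown here, the single exchange removes the aromatic ring and brings in a carbonyl and a non-aromatic ring at once, so the contribution of each remains unresolved. Also open, as far as these compounds go, is whether a saturated 3-phenylpropyl chain or a benzyl group at this place would keep a number close to that of compound 3.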